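The compounds below may be only part of what the source reports. "The series", "measured", "known", "first", "only" and "open" are said of these compounds alone.

In a functional assay on A549 cells (Homo sapiens) for antiproliferative activity, read by MTT assay, with a stated time of 72 h (a lower number here means a stronger inhibitor, a higher number a weaker inhibitor), three compounds have been measured so far. Compound 1 `O=C1NC(=O)/C(=C/C2=Cc3ccccc3OC2)S1` gives 192000 nM in this assay. Compound 2 `O=C1NC(=O)/C(=C/C2=Cc3ccccc3OC2)N1` gives 29700 nM in this assay, the lowest of the three numbers; how its core differs from that of compound 1 is not broken down here. Compound 3 `O=C1NC(=O)/C(=C/C2=Cc3cc(Br)ccc3OC2)S1` carries a single change on the core of compound 1, (bromo in place of hydrogen on an aromatic carbon). In this assay compound 3 gives 79500 nM. That change made a 2.4-fold lower number from compound 1 to compound 3 (0.38 log units; beyond the scatter).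

Compound 4 `O=C1NC(=O)/C(=C/C2=Cc3cc(Br)ccc3OC2)N1` is not yet measured. It carries the same kind of change on the core of compound 2, (bromo in place of hydrogen on an aromatic carbon), and the place of the change is described in the same words for both pairs.

Because the step of a 2.4-fold lower number from compound 1 to compound 3 (0.38 log units; beyond the scatter) was modest and beyond the scatter, a step of about the same size is expected here, a 2.3-fold lower number from compound 2 to compound 4 (0.36 log units; beyond the scatter). Compound 4 is therefore estimated at 13000 nM in this assay, with a likely range from 5000 nM to 35000 nM. Whether the core of compound 2 answers to the bromo change as the core of compound 1 did cannot be known from these three compounds alone.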

Compound 4, half-maximal inhibitory concentration: 19300 nM
Compound 4: the middle estimate sits 1.5-fold (0.17 log units) below what was measured; the range from low to high includes it.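

In this assay, putting bromo in place of hydrogen on the core of compound 2 gave a 1.5-fold lower number from compound 2 to compound 4 (0.19 log units; within the scatter), a step that on its own cannot be told apart from no change. Set beside the step on the core of compound 1, it shows no difference that these measurements can resolve, so the change carried from one core to the other as far as can be seen here: the same change on two cores in this assay, a 2.4-fold lower number (0.38 log units; beyond the scatter) from compound 1 to compound 3 and a 1.5-fold lower number (0.19 log units; within the scatter) from compound 2 to compound 4, 1.6-fold (0.20 log units) apart, within the scatter of two such steps This does not show that the two steps are equal or that bromo lowers the number on the core of compound 2, and it rests on a single pair for each core and on one group in one place.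

The compounds shown leave open whether a chloro or methoxy group, or an amine, on the same aromatic carbon would carry between the two cores in the same way. They also leave open how bromo would behave on another carbon of that six-membered aromatic ring.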